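This account rests on a few compounds, and the source may have more. Where it says the series, first, only, none or still open, it means among the compounds named here.

The three measured compounds and their results in an ADME assay on Vero cells (Chlorocebus sabaeus) for cytotoxicity (on this read-out higher numbers stand for lower toxicity in this test and lower numbers for higher toxicity in this test), are:

Compound 1, `O=C1C(=O)N(Cc2cn(CC(=O)N3CCN(c4cc5c(cc4F)c(=O)c(C(=O)O)cn5C4CC4)CC3)nn2)c2ccc(F)cc21`: 32 ug/mL
Compound 2, `CCO/N=C1/C(=O)N(Cc2cn(CC(=O)N3CCN(c4cc5c(cc4F)c(=O)c(C(=O)O)cn5C4CC4)CC3)nn2)c2ccccc21`: 64 ug/mL
Compound 3, `O=C1C(=O)N(Cc2cn(CC(=O)N3CCN(c4cc5c(cc4F)c(=O)c(C(=O)O)cn5C4CC4)CC3)nn2)c2ccccc21`: 16 ug/mL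

Compounds 1 and 3 share one core and differ in a single place, (fluoro in place of hydrogen on an aromatic carbon); this change gave a 2.0-fold higher number from compound 3 to compound 1 (0.30 log units; within the scatter). Compound 2 has a different core, and how its core differs from that of compound 3 is not broken down here. Compound 2 stands highest of the three numbers, within the scatter of compound 1 and beyond the scatter of compound 3.

Compound 4, `CCO/N=C1/C(=O)N(Cc2cn(CC(=O)N3CCN(c4cc5c(cc4F)c(=O)c(C(=O)O)cn5C4CC4)CC3)nn2)c2c(F)cccc21`, has not yet been measured. It arises from compound 2 by fluoro in place of hydrogen on an aromatic carbon. This is the same kind of change as that from compound 3 to compound 1, though not the same: there the new group sat meta to a fused ring and para to a fused ring, here it sits ortho to a fused ring and meta to a fused ring. Resting on that earlier step, which measured as a 2.0-fold higher number from compound 3 to compound 1 (0.30 log units; within the scatter), the step expected here is a 1.3-fold higher number from compound 2 to compound 4 (0.10 log units; within the scatter). Compound 4 is accordingly estimated at 80 ug/mL in this assay, expected to lie between 40 ug/mL and 160 ug/mL.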

Compound 4, half-maximal cytotoxic concentration: 16 ug/mL
Estimate against measurement, compound 4: 5.0-fold (0.70 log units) above; the measured number lies below the stated range.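

Fluoro in place of hydrogen on an aromatic carbon gave a 4.0-fold lower number from compound 2 to compound 4 (0.60 log units; beyond the scatter), and on this read-out the lower number stands for higher toxicity in this test. Set beside the earlier step, this shows that the change does not carry over as one fixed step between these two cores in this assay: the same change on two cores in this assay, a 2.0-fold higher number (0.30 log units; within the scatter) from compound 3 to compound 1 and a 4.0-fold lower number (0.60 log units; beyond the scatter) from compound 2 to compound 4, 8.0-fold (0.90 log units) apart, beyond the scatter of two such steps

This does not show why the two steps part, since the fluoro sits in a different place in each pair and the cores differ as well, so the two pairs cannot separate the effect of place from that of core.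

The compounds shown leave open what fluoro would do on the core of compound 2 in the place it holds in compound 1, and on the core of compound 3 in the place it holds in compound 4. They also leave open how a chloro or a methoxy group would read in either place.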